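Pyridyl ether series: removing the fluoro from compound 3

The source may report more compounds than this note shows. Statements on the series, on what has been measured and on what is new or still open speak of the compounds shown alone.

Measured in an ADME assay on the whole organism (Rattus norvegicus) for pharmacokinetics, using cassette dosing, at a dose of 1 mg/kg by the oral route; on this read-out higher numbers stand for higher oral bioavailability and lower numbers for lower oral bioavailability:
compound 1 `C[C@@H](Cn1c(=O)[nH]/c(=N\c2ccc(Oc3nccs3)cc2)n(Cc2ccc(Cl)cc2)c1=O)C(=O)O`: 41.4%
compound 2 `C[C@@H](Cn1c(=O)[nH]/c(=N\c2ccc(Oc3ccc(F)cn3)cc2)n(Cc2ccc(Cl)cc2)c1=O)C(=O)O`: 82.4%
compound 3 `C[C@@H](Cn1c(=O)[nH]/c(=N\c2ccc(Oc3cccc(F)n3)cc2)n(Cc2ccc(Cl)cc2)c1=O)C(=O)O`: 60%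

Of the three numbers, compound 3 at 60% is the second highest. The next structure is compound 4 `C[C@@H](Cn1c(=O)[nH]/c(=N\c2ccc(Oc3ccccn3)cc2)n(Cc2ccc(Cl)cc2)c1=O)C(=O)O`, not yet measured. The change is hydrogen in place of fluoro on an aromatic carbon, so 6-fluoropyridin-2-yl becomes pyridin-2-yl.

Going by the values given here, no measured step removes a fluoro, so the evidence is indirect. Moving the fluoro within the pyridine gave a modest step, a number 22.4 percentage points lower from compound 2 to compound 3 (beyond the scatter). Replacing 1,3-thiazol-2-yl gave a large step, a number 41 percentage points higher from compound 1 to compound 2 (beyond the scatter), and a modest one, a number 18.6 percentage points higher from compound 1 to compound 3 (beyond the scatter). Both fluoropyridines therefore stand higher than the thiazole, and the position of the fluoro matters in this pair. Neither shows the direction of its removal, so no step beyond the scatter is the working expectation, with wide uncertainty.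

The expected change is a number 5 percentage points higher from compound 3 to compound 4 (within the scatter). For compound 4 the estimated value is 65%, with an expected range of 45% to 85%.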

Compound 4, oral bioavailability: 52.8%
The estimate for compound 4 lay 12.2 percentage points above the measured number, and the stated range covers the measured number.
By their numbers in this assay, from the lowest: compound 1; then compounds 4 and 3 (each within the scatter of the next); then compound 2.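

Hydrogen in place of fluoro next to the ring nitrogen gives a number 7.2 percentage points lower from compound 3 to compound 4 (within the scatter) in this assay and so does not separate 6-fluoropyridin-2-yl from pyridin-2-yl at this place. The pyridine without fluoro still gives a number 11.4 percentage points higher from compound 1 to compound 4 (beyond the scatter) against the 1,3-thiazol-2-yl ether, while a number 29.6 percentage points lower from compound 2 to compound 4 (beyond the scatter) shows that 5-fluoropyridin-2-yl stands clear of pyridin-2-yl, so the fluoro counts in that position but shows no step beyond the scatter in the other. Nothing measured here gives a reason for these steps.

Left open is whether chloro, methoxy or a nitrile next to the ring nitrogen would stay level with pyridin-2-yl in this assay or come closer to 5-fluoropyridin-2-yl. Also open, going by these compounds, is whether an amine at that carbon would keep the number clear of the 1,3-thiazol-2-yl ether.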